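The source may report more compounds than this note shows. Statements on the series, on what has been measured and on what is new or still open speak of the compounds shown alone.

The three measured compounds, all read in a functional assay on CCRF-CEM cells (Homo sapiens) for cytotoxicity, read by cell counting, with a stated time of 3 days; a higher number here means a weaker inhibitor, a lower number a stronger inhibitor:
Compound 1, `C=C(Br)C(=O)Nc1ccc(/C=C2\SC(=O)N(Cc3ccc(Cl)cc3)C2=O)cc1`, gives 2800 nM.
Compound 2, `C=C(Br)C(=O)Nc1ccc(/C=C2\SC(=O)N(Cc3ccc(C(F)(F)F)cc3)C2=O)cc1`, gives 8000 nM.
Compound 3, `C=C(Br)C(=O)Nc1cccc(/C=C2\SC(=O)N(Cc3ccc(C(F)(F)F)cc3)C2=O)c1`, gives 920 nM.

Compounds 1 and 2 share one core and differ only by chloro in place of trifluoromethyl on an aromatic carbon; that change gave a 2.9-fold lower number from compound 2 to compound 1 (0.46 log units; beyond the scatter). Compound 3 is built on a different core, made of the same atoms joined differently; the difference between the two cores is not broken down here. Compound 4, `C=C(Br)C(=O)Nc1cccc(/C=C2\SC(=O)N(Cc3ccc(Cl)cc3)C2=O)c1`, has not yet been measured. It differs from compound 3 by chloro in place of trifluoromethyl on an aromatic carbon, the same change at the same place as between compound 2 and compound 1, now carried onto the core of compound 3. This step is expected to be of similar size, a 2.9-fold lower number from compound 3 to compound 4 (0.46 log units; beyond the scatter), because the same change gave a 2.9-fold lower number from compound 2 to compound 1 (0.46 log units; beyond the scatter) in this assay. Compound 4 is therefore estimated at 320 nM in this assay, with a likely range from 150 nM to 800 nM.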

Compound 4, half-maximal inhibitory concentration: 1400 nM
For compound 4 the middle estimate is 4.4-fold (0.64 log units) below the measured one; the measured number lies above the stated range.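

In this assay, the swap of trifluoromethyl for chloro did not carry over from one core to the other: the same change on two cores in this assay, a 2.9-fold lower number (0.46 log units; beyond the scatter) from compound 2 to compound 1 and a 1.5-fold higher number (0.18 log units; within the scatter) from compound 3 to compound 4, 4.3-fold (0.64 log units) apart, beyond the scatter of two such steps.

On the core of compound 3 the step is a 1.5-fold higher number from compound 3 to compound 4 (0.18 log units; within the scatter) and so cannot be told apart from no change at all. This shows that the effect of the swap differs between these two cores, but it does not show why, and two cores cannot tell how the swap would behave on a third.

The compounds shown leave open how a methoxy group, an amine or a carboxylic acid in the same place on the ring would compare with chloro and trifluoromethyl on either core. They also leave open whether the bromine is needed, since every compound here carries it.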